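The source may report more compounds than this note shows. Statements on the series, on what has been measured and on what is new or still open speak of the compounds shown alone.

Of the compounds shown here, three sharing one core have been tested in a functional assay on PC-12 cells (Rattus norvegicus) for cytotoxicity, read by MTT assay, with stated times of 2 h and 24 h, tested at 1 uM; a lower number here means a weaker effect, a higher number a stronger effect of the compound at the concentration tested. In this assay compound 1 `CC(C)c1ccc(-n2nc(-c3ccc(C(F)(F)F)cc3O)nc2-c2ccccc2O)cc1` gives 69.7%, compound 2 `Oc1cc(C(F)(F)F)ccc1-c1nc(-c2ccccc2O)n(-c2ccccc2F)n1` gives 63.4%, and compound 3 `Oc1cc(C(F)(F)F)ccc1-c1nc(-c2ccccc2O)n(-c2ccccc2C(F)(F)F)n1` gives 71%. Compound 3 stands highest of the three numbers shown, yet both others lie within the scatter of it, as a number 1.3 percentage points higher from compound 1 to compound 3 (within the scatter) and a number 7.6 percentage points higher from compound 2 to compound 3 (within the scatter) make clear. The change to compound 4 `COc1ccccc1-n1nc(-c2ccc(C(F)(F)F)cc2O)nc1-c1ccccc1O` is methoxy in place of trifluoromethyl on an aromatic carbon. Going by the values given here, no measured step exchanges trifluoromethyl for methoxy; the one step at this position is the exchange of fluoro for trifluoromethyl already mentioned, and the exchanges of the whole aryl group on the aromatic nitrogen, a number 6.3 percentage points lower from compound 1 to compound 2 (within the scatter) and the step to compound 3, also stay within the scatter. Compound 4 is therefore expected to show no step beyond the scatter, a number 3 percentage points lower from compound 3 to compound 4 (within the scatter). The estimate for compound 4 is 68%, with a range from 57% to 78%.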

Compound 4, a percentage reported as activity, at one concentration (the size of the read-out at that concentration, not a potency): 70.7%
Compound 4: the middle estimate sits 2.7 percentage points below what was measured; low and high end bracket the measured number.
By their numbers in this assay, from the lowest: compounds 2, 1, 4 and 3 (each within the scatter of the next).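

In this assay, the aromatic carbon ortho to a large group now carries methoxy as well as fluoro and trifluoromethyl, and a number 0.3 percentage points lower from compound 3 to compound 4 (within the scatter) and a number 7.3 percentage points higher from compound 2 to compound 4 (within the scatter) show that this position tolerates a hydrogen-bond acceptor, which neither earlier group offers, with no step beyond the scatter. The exchange of the whole aryl group, a number 1 percentage points higher from compound 1 to compound 4 (within the scatter), shows the same. Nothing available explains this flat result.

Still open, as far as these compounds go, is whether an amine or a carboxylic acid on this carbon would give a step beyond the scatter.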